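Pyridin-2-yl for 4-bromophenyl on the shared core

The source may report more compounds than this note shows. Statements on the series, on what has been measured and on what is new or still open speak of the compounds shown alone.

Compound 1 `C=C1C(=O)[C@]23C[C@@]1(O)CC[C@H]2c1ccc(O)c(C)c1[C@@H]3Cn1cc(-c2ccc(Br)cc2)nn1` gives 1300 nM in a functional assay on SMMC-7721 cells (Homo sapiens) for cytotoxicity, read by MTT assay, with a stated time of 4 days; on this read-out lower numbers stand for stronger inhibition and higher numbers for weaker inhibition. Among the compounds with values here, compound 2 `C=C1C(=O)[C@]23C[C@@]1(O)CC[C@H]2c1ccc(OS(=O)(=O)c2ccc(C)cc2)c(C)c1[C@@H]3Cn1cc(-c2ccc(Br)cc2)nn1`, carrying (4-methylphenyl)sulfonyl in place of hydrogen on an oxygen on an aromatic ring, gives 4320 nM in this assay; the step of a 3.3-fold higher number from compound 1 to compound 2 (0.52 log units; beyond the scatter) is the only one measured so far. Compound 3 `C=C1C[C@]23C[C@@]1(O)CC[C@@H]2c1cccc(C)c1[C@@H]3Cn1cc(-c2ccc(C(F)(F)F)cc2)nn1` reaches only a limit of the assay, > 20000 nM, and the limit of > 20000 nM in this assay, at which 1 of the 3 values shown sits, marks where that value sits. Among the two numbers shown, compound 2 stands highest, with compound 1 as its nearest neighbour.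

Compound 4 `C=C1C(=O)[C@]23C[C@@]1(O)CC[C@H]2c1ccc(OS(=O)(=O)c2ccc(C)cc2)c(C)c1[C@@H]3Cn1cc(-c2ccccn2)nn1` differs from compound 2 by pyridin-2-yl in place of 4-bromophenyl on an aromatic carbon. Within the data shown here, the one measured step changes a different place, the oxygen on the aromatic ring, so no measured step bears directly on this exchange, and no step beyond the scatter is expected from compound 2 to compound 4: a 1.1-fold lower number from compound 2 to compound 4 (0.03 log units; within the scatter). For compound 4 a value of 4000 nM is therefore expected, with a range from 1500 nM to 12000 nM.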

Compound 4, half-maximal inhibitory concentration: 2830 nM
Compound 4: the middle estimate sits 1.4-fold (0.15 log units) above what was measured, and the stated range covers the measured number.
By their numbers in this assay, from the lowest: compound 1; then compounds 4 and 2 (each within the scatter of the next). At a limit, above all of these: compound 3.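

Within the data shown here, this is the first measured step at this position: on the aromatic carbon of the five-membered aromatic ring with 3 nitrogen, with the (4-methylphenyl)sulfonyl group kept on the oxygen, pyridin-2-yl in place of 4-bromophenyl gives a 1.5-fold lower number from compound 2 to compound 4 (0.18 log units; within the scatter) in this assay. In this pair, then, replacing the bromine-bearing ring of carbon only with a ring holding 1 hetero atom and 1 hydrogen-bond acceptor does not move the number beyond the scatter. Nothing shown gives a reason for this result.

Going by these compounds, it remains open whether pyridin-2-yl at this carbon behaves the same way with hydrogen on the oxygen, as in compound 1. Also open, on these data alone, is how pyridin-4-yl, or a phenyl ring bearing an amine or a carboxylic acid, would read at the same carbon.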